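From a Piperidine Side Chain to a Diethylamino Chain

The source may report more compounds than this note shows. Statements on the series, on what has been measured and on what is new or still open speak of the compounds shown alone.

Measured in a functional assay on SK-BR-3 cells (Homo sapiens) for antiproliferative activity; on this read-out higher numbers stand for weaker inhibition and lower numbers for stronger inhibition:
Compound 1 `CC(=O)Oc1ccc(C(=O)Nc2cc3ccc(OCC4CCCN(C)C4)c(C)c3oc2=O)cc1CC=C(C)C`: 740 nM
Compound 2 `CC(=O)Oc1ccc(C(=O)Nc2cc3ccc(OCCC4CCCCN4)c(C)c3oc2=O)cc1CC=C(C)C`: 640 nM
Compound 3 `CC(C)=CCc1cc(C(=O)Nc2cc3ccc(OCC4CCCN(C)C4)c(C)c3oc2=O)ccc1O`: 1300 nM

Compound 3, at 1300 nM, has the highest number of the three, yet it lies within the scatter of compound 1 and only just beyond it from compound 2. Compound 4 `CCN(CC)CCCOc1ccc2cc(NC(=O)c3ccc(O)c(CC=C(C)C)c3)c(=O)oc2c1C` differs from compound 3 in its side chain alone: 2-(diethylamino)ethyl in place of 1-methylpiperidin-3-yl on a saturated chain carbon bound to an oxygen on an aromatic ring. The closest evidence is another side-chain swap, a 1.2-fold lower number from compound 1 to compound 2 (0.06 log units; within the scatter). The other measured step, a 1.8-fold higher number from compound 1 to compound 3 (0.24 log units; within the scatter), concerns the acetyl group, a change not made here. Among the measured compounds shown here, no measured compound carries a side chain without a ring, so this estimate remains uncertain. The expected step in this assay is a 1.1-fold lower number from compound 3 to compound 4 (0.03 log units; within the scatter), with no change expected beyond the scatter. For compound 4 the estimated value is 1200 nM, with an expected range of 500 nM to 2800 nM.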

Compound 4, half-maximal inhibitory concentration: 4900 nM
Compound 4: middle estimate off by 4.1-fold (0.61 log units), on the low side; measured number outside the range, above it.
By their numbers in this assay, from the lowest: compounds 2, 1 and 3 (each within the scatter of the next, the first and the last beyond it); then compound 4.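

In this assay, replacing 1-methylpiperidin-3-yl with 2-(diethylamino)ethyl gives a 3.8-fold higher number from compound 3 to compound 4 (0.58 log units; beyond the scatter), even though both groups have the same count of heavy atoms. Among the compounds shown here, the earlier side-chain swap, a 1.2-fold lower number from compound 1 to compound 2 (0.06 log units; within the scatter), gave no sign of this, so the new step is the first to show that the side chain at this position can move the number beyond the scatter. Nothing at hand explains the size of this step. As far as these compounds go, it remains open whether the loss follows from opening the ring or from the particular chain. A morpholine ring or a dimethylamino chain in the same place would help to tell these apart.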